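Chlorinated aryl swap on the methoxy series

A few compounds are considered here, and "the series" means these few. Any claim that something is new, unique, unknown or untested is made for them only; others in the source may bear on it.

Measured so far in a functional assay on MCF7 cells (Homo sapiens) for cytotoxicity, read by MTT assay, with a stated time of 72 h; on this read-out lower numbers stand for stronger inhibition and higher numbers for weaker inhibition
- compound 1 `COc1cccc(/C=C2\CCC/C(=C\c3cccc(Cl)c3Cl)C2=O)c1OC` gives > 20000 nM as a limit
- compound 2 `COc1ccc(/C=C2\CCC/C(=C\c3cccc(OC)c3OC)C2=O)cc1OC` gives 6500 nM as a number
- compound 3 `COc1ccccc1/C=C1\CCC/C(=C\c2ccc(OC)c(OC)c2)C1=O` gives 8000 nM as a number

Compound 3 gives 8000 nM and compound 2 gives 6500 nM in this assay so the two stand together within the scatter. The next change leads to compound 4 `COc1ccc(/C=C2\CCC/C(=C\c3cc(Cl)cc(Cl)c3)C2=O)cc1OC` with 3,5-dichlorophenyl in place of 2-methoxyphenyl on a double-bonded chain carbon bound to a double-bonded ring carbon as the counted difference.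

Within the data shown here, the only measured step is a 1.2-fold higher number from compound 2 to compound 3 (0.09 log units; within the scatter) for hydrogen in place of methoxy on an aromatic carbon. That step concerns a single methoxy, so it is a weak guide to replacing a whole aryl group. Among the measured compounds shown here, compound 1 is the only measured compound with chlorine on an aromatic ring, and its > 20000 nM is a limit. It differs from compound 4 in more than one place, so it only tilts the expectation toward higher numbers.

The expected step is a 1.8-fold higher number from compound 3 to compound 4 (0.24 log units; within the scatter) and it is estimated to point toward weaker inhibition. In this assay the estimate for compound 4 is 14000 nM with an expected range from 5000 nM to 20000 nM.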

Compound 4, half-maximal inhibitory concentration: 3800 nM
Beside the measured number, compound 4's estimate is 3.7-fold (0.57 log units) above it; measured number outside the range, below it.
By their numbers in this assay, from the lowest: compounds 4, 2 and 3 (each within the scatter of the next, the first and the last beyond it). At a limit, above all of these: compound 1.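

In this assay, among these compounds, putting 3,5-dichlorophenyl in place of 2-methoxyphenyl on a double-bonded chain carbon bound to a double-bonded ring carbon gives a 2.1-fold lower number from compound 3 to compound 4 (0.32 log units; beyond the scatter), whereas the only earlier step, a change of a single methoxy, gave a 1.2-fold higher number from compound 2 to compound 3 (0.09 log units; within the scatter). This position therefore accepts the exchange of a whole aryl group without a loss in this assay, and the oxygen of the leaving group, the one hydrogen-bond acceptor it carries, is not needed for compound 4 to reach 3800 nM. Nothing measured on these compounds accounts for the direction of the step.

From the compounds shown here alone, it remains open whether the lower number follows the two chlorines, their placement or the removal of the methoxy, as this single step changes all of these together. Also open, going by these compounds, is how the same position responds to an aryl group carrying an amine or a carboxylic acid, and whether the 3,5-dichlorophenyl group gives a similar step on other arrangements of methoxy groups on the far side of the shared core.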